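The compounds below may be only part of what the source reports. "The series", "measured", "known", "first", "only" and "open" are said of these compounds alone.

Of the compounds shown here, three have so far been measured in a functional assay on MCF7 cells (Homo sapiens) for cytotoxicity, with a stated time of 3 days; on this read-out lower numbers stand for stronger inhibition and higher numbers for weaker inhibition. Compound 1 `Clc1ccc(-c2cc(-c3cccs3)nc(-c3cccs3)c2)o1` gives > 100000 nM, which is a limit of the assay rather than a number. Compound 2 `Clc1ccc(-c2cc(-c3ccsc3)nc(-c3cccs3)c2)o1` gives > 100000 nM, again only a limit. Compound 3 `Cc1ccsc1-c1cc(-c2ccco2)cc(-c2cccs2)n1` gives > 100000 nM, also a limit. Compound 3 therefore stands exactly where the other two stand, at the limit of > 100000 nM in this assay, at which 3 of the 3 values shown sit, and no ordering among the three can be read from these results.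

The compound not yet measured is compound 4 `Cc1ccsc1-c1cc(-c2ccco2)cc(-c2ccsc2)n1`. Compared with compound 3 it differs in a single place: thiophen-3-yl in place of thiophen-2-yl on an aromatic carbon. The same exchange has been measured once before, as the step that the two limits leave unreadable from compound 1 to compound 2, where both ends sit at the limit and the size of the step cannot be read. That step is the only one that bears on the present change, and it supplies no number. The expectation for compound 4 in this assay is therefore that it, too, will most likely be reported only as a limit, with the step that the limit leaves unreadable from compound 3 to compound 4 expected to stay within the scatter. Compound 4 is estimated at 150000 nM, within a range from 50000 nM to 500000 nM.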

Compound 4, half-maximal inhibitory concentration: > 100000 nM
Compound 4 ended at the assay's limit; the forecaster's own chance of this, stated with the estimate: 90%; the middle value is on the limit's open side.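

In this assay, compound 3 and compound 4 both sit at a limit rather than a number, so the size of the step between them cannot be read. The compounds shown leave open whether exchanging thiophen-2-yl for thiophen-3-yl changes cytotoxicity at all, and none can be ranked against another: the limit of > 100000 nM in this assay, at which 4 of the 4 values shown sit.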